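Sulfonamide amine swap on the aryloxyacetic acid series

The source may hold more compounds than are shown below. What is called first, only, known or untested is meant among the compounds shown, and "the series" means these compounds.

Compound 1 `Cc1ccc(S(=O)(=O)N(C)CC(C)C)cc1C#Cc1cc(Cl)ccc1OCC(=O)O` is the reference point of the set. In an assay on CHO cells for displacement of a labelled ligand from prostaglandin D2 receptor 2 (Homo sapiens), read by scintillation counting (a lower number here means a stronger inhibitor, a higher number a weaker inhibitor), compound 1 gives 4.2 nM, the lowest number among the three measured compounds and beyond the scatter from both of the others, so it is the strongest inhibitor shown. Compound 2 `O=C(O)COc1ccc(Cl)cc1C#Cc1ccc2c(c1)S(=O)(=O)CC2` carries a different group on the alkyne end of the shared core and in this assay compound 2 gives 23 nM. Compound 3 `O=C(O)COc1ccc(Cl)cc1C#Cc1cccnc1` has a smaller aromatic group in the same region and in this assay compound 3 gives 117 nM. Going by the values given here, no single-site step between the measured compounds is available, so the spread among them cannot be assigned to one change.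

The compound under consideration is compound 4 `Cc1ccc(S(=O)(=O)N2CCCCC2C)cc1C#Cc1cc(Cl)ccc1OCC(=O)O`. It differs from compound 1 at the sulfonamide: 2-methylpiperidin-1-yl in place of isobutyl(methyl)amino on a sulfonyl sulfur. Both groups are saturated amines without donors or acceptors beyond the sulfonyl, and the heavy-atom count rises by one. Nothing in the measured set tests this part of the structure, so no direction is evident. The expectation is a step from compound 1 to compound 4 of a 1.3-fold higher number from compound 1 to compound 4 (0.12 log units; within the scatter), within the scatter. Compound 4 is therefore estimated at 5.5 nM, with a range from 2 nM to 15 nM.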

Compound 4, inhibition constant: 1.9 nM
Compound 4: the middle estimate sits 2.9-fold (0.46 log units) above what was measured, outside the stated range (below it).
By their numbers in this assay, from the lowest: compound 4; then compound 1; then compound 2; then compound 3.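

The sulfonamide amine now has its own single-site step: in this assay, 2-methylpiperidin-1-yl in place of isobutyl(methyl)amino on a sulfonyl sulfur gives a 2.2-fold lower number from compound 1 to compound 4 (0.34 log units; beyond the scatter) and so moves towards a stronger inhibitor, modestly but beyond the scatter. The earlier compounds shown here varied only the group on the alkyne end, whereas this step shows that the number also responds to the amine on the sulfonyl. An open-chain amine is not required here, since a six-membered ring with one more heavy atom is accepted with no loss. No measurement at hand bears on why the number falls, so the step stands as an observation only.

A single step cannot separate the effect of closing the ring from that of its methyl group: plain piperidin-1-yl would divide the two, while pyrrolidin-1-yl and morpholin-4-yl would probe ring size and a ring oxygen. From the compounds shown here alone, it also remains open whether the two mirror-image forms of the 2-methylpiperidin-1-yl group give the same number.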